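This account rests on a few compounds, and the source may have more. Where it says the series, first, only, none or still open, it means among the compounds named here.

Measured so far in a functional assay on HEK293 cells for agonist activity at Vasopressin V2 receptor (Homo sapiens), read by a luciferase reporter and cAMP accumulation; a higher number here means that more compound is needed for the effect, a lower number that less compound is needed: compound 1 `Cc1cc(C(=O)N2CCCCc3ccccc32)ccc1CNC(=O)Nc1ccccc1F` gives 30 nM; compound 2 `Cc1cc(C(=O)N2CCCCc3ccccc32)ccc1CNC(=O)NCC(=O)N1CCCCC1` gives 150 nM; compound 3 `Cc1cc(C(=O)N2CCCCc3ccccc32)ccc1CNC(=O)N1CCC[C@H]1C(=O)O` gives 680 nM.

Compound 3 stands highest of the three numbers in this assay: a 23-fold higher number from compound 1 to compound 3 (1.36 log units; beyond the scatter) and a 4.5-fold higher number from compound 2 to compound 3 (0.66 log units; beyond the scatter). Compound 4 `Cc1cc(C(=O)N2CCCCc3ccccc32)ccc1CNC(=O)N1CCC[C@H]1C(=O)OC(C)(C)C` differs from compound 3 by tert-butyl in place of hydrogen on an oxygen next to a carbonyl group. Among the measured compounds shown here, no measured step covers an ester in place of a carboxy group; the steps bearing indirectly on it are those that reach compound 3, both beyond the scatter, which show the carboxy-bearing compound as the weakest so far. The change is therefore expected to lower the number modestly, with wide uncertainty. For compound 4 the estimate is 200 nM (range 50 nM to 1500 nM), meaning an expected step of a 3.4-fold lower number from compound 3 to compound 4 (0.53 log units; beyond the scatter).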

Compound 4, half-maximal effective concentration: 390 nM
Compound 4: middle estimate off by 2.0-fold (0.29 log units), on the low side; measured number inside the range.
By their numbers in this assay, from the lowest: compound 1; then compound 2; then compounds 4 and 3 (each within the scatter of the next).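

In this assay replacing carboxy with tert-butoxycarbonyl does not separate the two compounds (a 1.7-fold lower number from compound 3 to compound 4 (0.24 log units; within the scatter)), so the free carboxy group alone does not account for the distance of compound 3 from compounds 1 and 2. The 2-(tert-butoxycarbonyl)pyrrolidin-1-yl group still stays apart from both other groups on that carbonyl carbon (a 2.6-fold higher number from compound 2 to compound 4 (0.41 log units; beyond the scatter); a 13-fold higher number from compound 1 to compound 4 (1.11 log units; beyond the scatter)). No measurement shown gives a reason for these steps.

Open, on these data alone, is whether a methyl ester or a primary amide would stand with compound 4, and whether unsubstituted pyrrolidin-1-yl would approach compound 1.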